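Fluoro Added to Compound 3: What to Expect

The source may report more compounds than this note shows. Statements on the series, on what has been measured and on what is new or still open speak of the compounds shown alone.

Of the compounds shown here, three sharing a common core have been read in a functional assay on DLD-1 cells (Homo sapiens) for antiproliferative activity, read by trypan blue exclusion; a higher number here means a weaker inhibitor, a lower number a stronger inhibitor. Compound 1 `COc1ccc(CS(=O)(=O)/C=C/c2ccccc2OC)cc1` gives 7500 nM. Compound 2 `COc1ccc(CS(=O)(=O)/C=C/c2ccc(OC)c(OC)c2)cc1` returns only a limit of the assay, > 20000 nM, and not a number. Compound 2 thus sits at the limit of > 20000 nM in this assay, at which 1 of the 3 values shown sits. Compound 3 `COc1ccc(CS(=O)(=O)/C=C/c2c(OC)cccc2OC)cc1` gives 700 nM, the lowest of the two numbers shown, with compound 1 as its nearest neighbour. Within the data shown here, the single step that can be followed between measured compounds is an 11-fold lower number from compound 1 to compound 3 (1.03 log units; beyond the scatter), a large change brought by methoxy in place of hydrogen on an aromatic carbon.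

Compound 4 `COc1ccc(CS(=O)(=O)/C=C/c2c(OC)cc(F)cc2OC)cc1` is the next member and has not yet been measured in this assay. It differs from compound 3 in one place: fluoro in place of hydrogen on an aromatic carbon. Among the measured compounds shown here, no measured step involves fluoro, and the step from compound 1 to compound 3 concerns a methoxy group, so it offers no direct guide to what a fluoro in this position will do. Without a bearing step, the expected step of a 1.2-fold lower number from compound 3 to compound 4 (0.07 log units; within the scatter) is taken to lie within the usual scatter. Compound 4 is therefore estimated at 600 nM, with a range from 150 nM to 2500 nM.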

Compound 4, half-maximal inhibitory concentration: 750 nM
The estimate for compound 4 lay 1.3-fold (0.10 log units) below the measured number, within the range that was stated.
By their numbers in this assay, from the lowest: compounds 3 and 4 (each within the scatter of the next); then compound 1. At a limit, above all of these: compound 2.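

In this assay, fluoro in place of hydrogen gives a 1.1-fold higher number from compound 3 to compound 4 (0.03 log units; within the scatter), so at this aromatic carbon, meta to two methoxy groups and para to a large group, the change leaves no readable mark on the number. The earlier compounds offered only one followable step, a methoxy in place of hydrogen that gave an 11-fold lower number from compound 1 to compound 3 (1.03 log units; beyond the scatter), and so they showed that a change on this ring can move the number far; this result adds a position and a change on the same ring where it does not, and it is the only step shown at this carbon. Nothing among the data shown offers a reason for this small step.

From the compounds shown here alone, what a larger or differently built group would do at this same carbon stays open, since a single fluoro says nothing about a chloro, a hydroxyl, an amine or a carboxylic acid placed there. Going by these compounds, it also stays open whether fluoro would give an equally small step on the core of compound 1, which carries one methoxy fewer than compound 3.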